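Working notes: aryl ether change from compound 3 to compound 4

This account rests on a few compounds, and the source may have more. Where it says the series, first, only, none or still open, it means among the compounds named here.

Compound 1 `Cc1nn(C)c(Oc2cccc(F)c2)c1/C=N\CCCCCOc1cc2oc(=O)cc(C)c2cc1Cl` — 13400 nM in a functional assay on HepG2 cells (Homo sapiens) for antiproliferative activity, read by MTT assay, with a stated time of 72 h; a higher number here means a weaker inhibitor, a lower number a stronger inhibitor; a higher number here means a weaker inhibitor.
Compound 2 `Cc1nn(C)c(Oc2ccc(I)cc2)c1/C=N\CCCCCOc1cc2oc(=O)cc(C)c2cc1Cl` — only a limit, > 25000 nM.
Compound 3 `Cc1nn(C)c(Oc2ccc(F)c(F)c2)c1/C=N\CCCCCCOc1cc2oc(=O)cc(C)c2cc1Cl` — only a limit, > 25000 nM.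

Compound 3 stands at the assay limit, which the limit of > 25000 nM in this assay, at which 2 of the 3 values shown sit, shows it shares with compound 2. Within the data shown here, the only measured step, an at least 1.8-fold higher number from compound 1 to compound 2 (0.27 log units; that floor lies within the scatter), also varies the aryl ether, and its floor sits within the scatter, so it resolves nothing about direction. Compound 4 `Cc1nn(C)c(Oc2cccc(C(F)(F)F)c2)c1/C=N\CCCCCCOc1cc2oc(=O)cc(C)c2cc1Cl` differs from compound 3 by 3-(trifluoromethyl)phenyl in place of 3,4-difluorophenyl on an oxygen on an aromatic ring. Among the measured compounds shown here, no measured step covers this change. Compound 4 is expected to remain near the limit, with a number no higher from compound 3 to compound 4 (the limit leaves the size open) expected to stay within the scatter. The estimate for compound 4 in this assay is 25000 nM, ranging from 8000 nM to 60000 nM.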

Compound 4, half-maximal inhibitory concentration: > 25000 nM
Compound 4 was reported as a limit; the forecaster's own chance of this, stated with the estimate: 60%; the middle value lies on the limit itself.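

Among these compounds, compound 3 and compound 4 both stand only as limits, so no step between them can be read: the limit of > 25000 nM in this assay, at which 3 of the 4 values shown sit. The compounds shown leave open whether 3,4-difluorophenyl and 3-(trifluoromethyl)phenyl differ at all in this assay.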